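Replacing piperidin-1-yl on a thiocarbonyl carbon: working notes

This account rests on a few compounds, and the source may have more. Where it says the series, first, only, none or still open, it means among the compounds named here.

In a functional assay on A549 cells (Homo sapiens) for antiproliferative activity, read by MTT assay, with a stated time of 48 h (a lower number here means a stronger inhibitor, a higher number a weaker inhibitor), compound 1 (`O=C(Nc1ccc(Cl)cc1)Nc1cccc(NC(=O)c2ccccn2)c1`) gives 3620 nM as its half-maximal inhibitory concentration. Compound 2 (`O=C(Nc1cccc(NC(=S)Nc2ccc([N+](=O)[O-])cc2)c1)c1ccccn1`) gives 450 nM in the same read-out. Compound 3 (`O=C(CSC(=S)N1CCCCC1)Nc1cccc(NC(=O)c2ccccn2)c1`) gives 320 nM and so stands within the scatter of compound 2. The number of compound 1 is higher than that of compound 3, beyond the scatter.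

Compound 4 (`CCN1CCN(C(=S)SCC(=O)Nc2cccc(NC(=O)c3ccccn3)c2)CC1`) carries 4-ethylpiperazin-1-yl in place of piperidin-1-yl on a thiocarbonyl carbon. Among the measured compounds shown here, no two measured compounds differ in one place only, so the series offers no direct precedent for the size of this step. In this assay no step beyond the scatter is expected, and no direction is favoured with confidence. The estimate therefore rests on compound 3 at 320 nM as the closest measured structure. The expected move is a 1.3-fold higher number from compound 3 to compound 4 (0.10 log units; within the scatter) and stays within the scatter. For compound 4 the estimated value is 400 nM with an expected range from 130 nM to 1200 nM in this measurement.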

Compound 4, half-maximal inhibitory concentration: 3720 nM
Beside the measured number, compound 4's estimate is 9.3-fold (0.97 log units) below it; the measured number lies above the stated range.
By their numbers in this assay, from the lowest: compounds 3 and 2 (each within the scatter of the next); then compounds 1 and 4 (each within the scatter of the next).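

In this assay, among the compounds shown here, the group on a thiocarbonyl carbon whose other neighbours are sulfur turns out to matter: 4-ethylpiperazin-1-yl in place of piperidin-1-yl gives a 12-fold higher number from compound 3 to compound 4 (1.07 log units; beyond the scatter), the first single-place comparison and a large one. The position therefore does not accept every six-membered non-aromatic ring equally, at least in this pair, though the entering group differs by both a second ring nitrogen and an ethyl group, and this one step cannot separate the two. Nothing available on these compounds accounts for the size of the step.

Open, going by these compounds, is whether the unsubstituted piperazin-1-yl or morpholin-4-yl would read like compound 3 or like compound 4. Also open, on these data alone, is whether a 4-methylpiperazin-1-yl group would differ from the 4-ethyl group in compound 4.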